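A Methyl on an Aromatic Nitrogen: Compound 1 to Compound 4

A few compounds are considered here, and "the series" means these few. Any claim that something is new, unique, unknown or untested is made for them only; others in the source may bear on it.

In an in vivo ADME assay on the whole organism for pharmacokinetics, with Rattus norvegicus as the target, at a dose of 5 mg/kg by the oral route (a higher number here means that a larger share of the oral dose reaches the circulation, a lower number that a smaller share of the oral dose reaches the circulation), compound 1 `CC(=O)Nc1cc(-c2c(Nc3cc[nH]n3)nc3cccnn23)nc(C)n1` gives 46%, the highest of the three numbers here. Compound 2 `CNc1cc(-c2c(Nc3cc[nH]n3)nc3cccnn23)nc(C)n1` gives 29%, and compound 3 `CC(=O)Nc1cc(-c2c(Nc3ccn(C)n3)nc3ccccn23)nc(C)n1` gives 4%. Compound 4 `CC(=O)Nc1cc(-c2c(Nc3ccn(C)n3)nc3cccnn23)nc(C)n1` differs from compound 1 by methyl in place of hydrogen on an aromatic nitrogen. Within the data shown here, the only step measured between compounds that differ in one place, a number 17 percentage points lower from compound 1 to compound 2 (beyond the scatter), concerns another position and so bears only loosely on this change. Compound 3 carries the same methyl on that nitrogen but also a different core, so its much lower number cannot be split between the two changes. A drop of moderate size is therefore expected, a number 18 percentage points lower from compound 1 to compound 4 (beyond the scatter), though with wide uncertainty. Compound 4 is estimated at 28%, between 8% and 52%.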

Compound 4, oral bioavailability: 34%
Estimate against measurement, compound 4: 6 percentage points below; measured number inside the range.
By their numbers in this assay, from the lowest: compound 3; then compounds 2 and 4 (each within the scatter of the next); then compound 1.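

In this assay, methyl in place of hydrogen on the aromatic nitrogen, with nothing else changed, gives a number 12 percentage points lower from compound 1 to compound 4 (beyond the scatter) as a modest step. The loss is now seen apart from any change of core, and compound 4 still keeps 34% of the oral dose in the circulation. No measurement here says why the number falls.

Going by these compounds, whether ethyl, a longer chain or a hydroxyethyl group on that nitrogen would cost more or less stays open. So does the size of the same step on the core of compound 3, whose partner with hydrogen on that nitrogen is not among these compounds.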